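Azido to methylsulfanyl on the core of compound 1

The source may hold more compounds than are shown below. What is called first, only, known or untested is meant among the compounds shown, and "the series" means these compounds.

Among the measured compounds shown here, two measured compounds frame the series so far. Compound 1 `[N-]=[N+]=Nc1nccc2c1ncn2[C@H]1C[C@H](O)[C@@H](CO)O1` gives 13% in a functional assay on EL4 cells (Mus musculus) for inhibition, tested at 100 uM (a higher number here means more inhibition at the concentration tested (going by the name of the read-out), a lower number less inhibition), the highest of the two numbers in hand. Compound 2 `OC[C@H]1OC(n2cnc3c(Nc4ccccc4)nccc32)[C@H](O)[C@@H]1O` gives 10% in this assay; its gap to compound 1 lies within the scatter, so the two read as equivalent, and both sit near the bottom of the scale at the concentration tested.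

Compound 3 `CSc1nccc2c1ncn2[C@H]1C[C@H](O)[C@@H](CO)O1` has not been measured. It differs from compound 1 in one place: methylsulfanyl in place of azido on an aromatic carbon. For the measured compounds named here, no step between measured compounds resembles this exchange, so the series itself gives no guide to how the read-out responds to a change of this kind. With both measured compounds close to zero inhibition, the expectation for compound 3 is a step of a number 1 percentage points lower from compound 1 to compound 3 (within the scatter) of no size beyond the scatter, in no particular direction. Compound 3 is therefore estimated at 12%, with a plausible range from 0% to 30%.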

Compound 3, a percentage reported as inhibition, at one concentration (the size of the read-out at that concentration, not a potency): < 5%
Compound 3 ended at the assay's limit; the forecaster's own chance of this, stated with the estimate: 0%; middle value at least 7 percentage points from the limit.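

In this assay compound 3 reads < 5%, which is a limit of the assay and not a number. The exchange of azido for methylsulfanyl on the aromatic carbon next to the ring nitrogen gives the series its first step at a single place, a number at least 8 percentage points lower from compound 1 to compound 3 (that floor lies within the scatter), so the change cannot be called a loss beyond the scatter, nor can the true size of the step be read. This position therefore takes a group of quite different atoms, with nitrogen leaving and carbon and sulfur entering, without any read-out clearly above the bottom of the scale appearing, and the new value adds to what sits at the floor of the measurable range: the limit of < 5% in this assay, at which 1 of the 3 values shown sits.

From the compounds shown here alone, whether an amine, a methoxy group or a longer alkylsulfanyl chain at this position would lift inhibition clear of the scatter in this assay stays open. Compound 2 differs from compound 1 and compound 3 in more than one place, so what the rest of the molecule contributes remains unresolved.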